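This account rests on a few compounds, and the source may have more. Where it says the series, first, only, none or still open, it means among the compounds named here.

For the measured compounds named here, compound 2 `NCc1ccc(C(=O)Nc2cccc(NC(=O)COc3ccc4c(=O)ccoc4c3)c2)cc1` gives 66 nM in an assay on isolated protein for inhibition of Rho-associated protein kinase 2 (Homo sapiens), read by scintillation counting, radiometric assay and 33P incorporation, with a stated time of 40 min, in the presence of a further agent that is not named here (on this read-out higher numbers stand for weaker inhibition and lower numbers for stronger inhibition), the higher of the two numbers measured so far; its only neighbour is compound 1 `CCOc1ccc(C(=O)Nc2cccc(NC(=O)COc3ccc4c(=O)ccoc4c3)c2)cc1`, which gives 9 nM, and a 7.3-fold higher number from compound 1 to compound 2 (0.87 log units; beyond the scatter) separates the two. Compound 3 `Nc1cccc(C(=O)Nc2cccc(NC(=O)COc3ccc4c(=O)ccoc4c3)c2)c1` is not yet measured. It differs from compound 2 in one place: 3-aminophenyl in place of 4-(aminomethyl)phenyl on a carbonyl carbon. Going by the values given here, no measured step exchanges one amine-bearing ring for another; the single step on record, a 7.3-fold higher number from compound 1 to compound 2 (0.87 log units; beyond the scatter), changes the group on an aromatic carbon and shifted the number modestly, so a change of comparable size is the most that these data support. Neither direction is favoured by the two values at hand. Compound 3 is therefore expected to land near compound 2, with the estimate 100 nM and a range from 25 nM to 400 nM. This expectation corresponds to a step of a 1.5-fold higher number from compound 2 to compound 3 (0.18 log units; within the scatter).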

Compound 3, half-maximal inhibitory concentration: 58 nM
For compound 3 the middle estimate is 1.7-fold (0.24 log units) above the measured one; the measured number falls inside the stated range.
By their numbers in this assay, from the lowest: compound 1; then compounds 3 and 2 (each within the scatter of the next).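

In this assay the position on the carbonyl carbon accepts either amine-bearing ring without a readable difference: exchanging 4-(aminomethyl)phenyl for 3-aminophenyl gives a 1.1-fold lower number from compound 2 to compound 3 (0.06 log units; within the scatter). The amine can therefore sit directly on the ring or on a methylene arm, and at a different ring position, and the number stays within the scatter for this pair. Compound 1 keeps its separation from this second amine as well, with a 6.4-fold higher number from compound 1 to compound 3 (0.81 log units; beyond the scatter), so among these three compounds, both amine-bearing rings read apart from 4-ethoxyphenyl. No measurement available here bears on why the two amine-bearing rings read alike.

As far as these compounds go, because ring position and the methylene arm changed together in this step, their separate contributions remain open. So does how 4-aminophenyl or 3-(aminomethyl)phenyl, which would separate them, or a carboxylic acid on the same ring would read.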